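Hydroxy for trifluoromethyl on the aryl of compound 3

A few compounds are considered here, and "the series" means these few. Any claim that something is new, unique, unknown or untested is made for them only; others in the source may bear on it.

Compound 3 `CCc1nc(-c2ccc(OC)cc2C(F)(F)F)c(CC)nc1NC(CC)CC` stands second highest of the three numbers in an assay on IMR-32 cells for displacement of a labelled ligand from corticotropin-releasing factor receptor 1 (Homo sapiens), read by scintillation counting, with a stated time of 2 h (a lower number here means a stronger inhibitor, a higher number a weaker inhibitor), giving 4.4 nM. Its nearest neighbour is compound 2 `CCc1nc(NC(CC)CC)c(OC)nc1-c1ccc(OC)cc1C(F)(F)F`, which in this assay gives 2.2 nM; the step of a 2.0-fold higher number from compound 2 to compound 3 (0.30 log units; within the scatter) lies within the scatter. The furthest is compound 1 `CCOc1nc(-c2ccc(Cl)cc2Cl)c(CC)nc1NC(CC)CC`, which in this assay gives 151 nM, a gap beyond the scatter, but compound 1 differs from compound 3 in more than one place, so no single step can be read from it.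

Compound 4 `CCc1nc(-c2ccc(OC)cc2O)c(CC)nc1NC(CC)CC` is the next step: hydroxy in place of trifluoromethyl on an aromatic carbon. The group sits ortho to a large group and meta to a methoxy group. Going by the values given here, no measured step touches this place on the aryl; the one step in hand, a 2.0-fold higher number from compound 2 to compound 3 (0.30 log units; within the scatter), concerns another position and stayed within the scatter, so it gives no guide to this change. Lacking a precedent, the expected step of an 11-fold higher number from compound 3 to compound 4 (1.06 log units; beyond the scatter) is a loss beyond the scatter rather than a gain. Compound 4 is expected in this assay to give about 50 nM, with a range from 8 nM to 400 nM.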

Compound 4, inhibition constant: 1180 nM
Compound 4: the middle estimate sits 24-fold (1.37 log units) below what was measured; measured number outside the range, above it.
By their numbers in this assay, from the lowest: compounds 2 and 3 (each within the scatter of the next); then compound 1; then compound 4.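

In this assay, going by these compounds alone, the place ortho to a large group and meta to a methoxy group proves highly sensitive to what stands on it: hydroxy in place of trifluoromethyl gives a 270-fold higher number from compound 3 to compound 4 (2.43 log units; beyond the scatter), whereas the only earlier single-place step, a 2.0-fold higher number from compound 2 to compound 3 (0.30 log units; within the scatter), concerns another position. This single step cannot separate the departure of trifluoromethyl from the arrival of hydroxy, as the heavy-atom count and the hydrogen-bond donor count change together. No measurement in hand accounts for the size of this loss.

The compounds shown leave open how a methyl group, a fluorine atom or an amine would read at this place, which could help show how far the outcome tracks the hydrogen-bond donor. Also open, on these data alone, is whether hydroxy for trifluoromethyl on compound 2 would give a step of similar size.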